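Phenethyl on sulfur: notes on compound 3

This account rests on a few compounds, and the source may have more. Where it says the series, first, only, none or still open, it means among the compounds named here.

Measured in a functional assay on SMMC-7721 cells (Homo sapiens) for inhibition, read by CCK-8 assay, with a stated time of 72 h, tested at 8 uM; a lower number here means less inhibition of growth, a higher number more inhibition of growth at the concentration tested:
- compound 1 `Nc1ccccc1NC(=O)/C=C/c1ccc(CSc2ccc(C(F)(F)F)cn2)cc1`: 20.1%
- compound 2 `Nc1ccccc1NC(=O)c1ccc(CSc2ccc(Br)cc2)cc1`: 25.3%

Compound 1 stands within the scatter of compound 2, so the two measured values cannot be told apart. Compound 3 `Nc1ccccc1NC(=O)/C=C/c1ccc(CSCCc2ccccc2)cc1` has phenethyl in place of 5-(trifluoromethyl)pyridin-2-yl on a sulfur. Among the measured compounds shown here, no measured compound carries phenethyl there, so the data give no direct guide to this change. In this assay the expected step of a number 3.9 percentage points higher from compound 1 to compound 3 (within the scatter) stays within the scatter, with no firm direction. For compound 3 the estimated value is 24%, with an expected range of 8% to 48%.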

Compound 3, percent growth inhibition at one concentration: 15.8%
Estimate against measurement, compound 3: 8.2 percentage points above; measured number inside the range.
By their numbers in this assay, from the lowest: compounds 3, 1 and 2 (each within the scatter of the next).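

In this assay the series now has a step that changes one place: phenethyl in place of 5-(trifluoromethyl)pyridin-2-yl on a sulfur gives a number 4.3 percentage points lower from compound 1 to compound 3 (within the scatter) and so does not separate the two compounds. On this sulfur, phenethyl, with its carbon-only aromatic ring and no nitrogen or fluorine, cannot be told apart from the 5-(trifluoromethyl)pyridin-2-yl group at the concentration tested. Nothing at hand bears on a cause for this result.

On these data alone, whether an amine, a carboxylic acid or a longer chain on this sulfur would move the number beyond the scatter stays open.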